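The source may hold more compounds than are shown below. What is called first, only, known or untested is meant among the compounds shown, and "the series" means these compounds.

Working notes on the series.

Compound 1 `CCCCCCCCCCC#CCOCc1ccc(CCCC(=O)O)cc1` and compound 2 `CCCCCCCCCCC#CCOCc1ccc(C(=O)O)cc1` share a core and differ in one place. In an assay on isolated protein for inhibition of Arachidonate 12-lipoxygenase (Sus scrofa) (on this read-out lower numbers stand for stronger inhibition and higher numbers for weaker inhibition), compound 1 gives only a limit, > 10000 nM, and no number. In this assay compound 2 gives 60 nM. For the measured compounds named here, the single measured step, an at least 160-fold lower number from compound 1 to compound 2 (2.22 log units; beyond the scatter), is therefore read against the limit of > 10000 nM in this assay, at which 1 of the 2 values shown sits, and its true size is not known beyond the bound. Going by the values given here, compound 2 holds the only number in the set; the other entry is a limit.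

Compound 3 `CCCCCCCC#CCOCc1ccc(C(=O)O)cc1` differs from compound 2 by hydrogen in place of propyl on a saturated chain carbon, seven bonds along the chain from a triple-bonded carbon. Among the compounds with values here, no measured step touches the chain on this side of the triple bond; the one step in hand, an at least 160-fold lower number from compound 1 to compound 2 (2.22 log units; beyond the scatter), concerns the acid-bearing end and so bears on the present change only as a reminder that the series is sensitive to single alterations. Within the data shown here, with no direct precedent, the expected movement rests on the structural change alone and the chain shortening is taken to weaken inhibition modestly. Compound 3 is expected to come out at 300 nM, a range of 60 nM to 3000 nM, which means an estimated step of a 5.0-fold higher number from compound 2 to compound 3 (0.70 log units; beyond the scatter) in this assay.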

Compound 3, half-maximal inhibitory concentration: 6000 nM
Beside the measured number, compound 3's estimate is 20-fold (1.30 log units) below it; the measured number lies above the stated range.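

The step of a 100-fold higher number from compound 2 to compound 3 (2.00 log units; beyond the scatter) in this assay shows that hydrogen in place of propyl on a saturated chain carbon, seven bonds along the chain from a triple-bonded carbon, is a large change in its own right. For the compounds shown here, the series therefore responds strongly at a second place, since the only earlier step, an at least 160-fold lower number from compound 1 to compound 2 (2.22 log units; beyond the scatter), came from carboxy in place of 3-carboxypropyl on an aromatic carbon. The data in hand give no reason for the size of the new step.

On these data alone, with only the chains of compound 2 and compound 3 to compare, it stays open whether the number climbs gradually or abruptly as the chain is cut, and a methyl or ethyl group in place of the propyl would be needed to separate those readings. As far as these compounds go, it also stays open whether a longer chain than that of compound 2 would lower the number further or raise it, and whether a hydroxyl group at the chain end would be tolerated at all.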